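Fluoro at a Second Place on the Shared Core

This account rests on a few compounds, and the source may have more. Where it says the series, first, only, none or still open, it means among the compounds named here.

Compound 1 `O=C(NCCCCc1ccccc1)n1c(=O)oc2ccccc21`: 64 nM
Compound 2 `O=C(NCCCCc1ccccc1)n1c(=O)oc2ccc(F)cc21`: 12 nM
Compound 3 `O=C(NCCCCc1ccc(F)cc1)n1c(=O)oc2ccccc21`: 75 nM

Of the compounds shown here, three have been measured in an assay on HEK293 cells for inhibition of acid ceramidase (Homo sapiens), with a stated time of 10 min; a higher number here means a weaker inhibitor, a lower number a stronger inhibitor. Compound 1 stands second highest of the three numbers, with compound 3 nearest and compound 2 furthest. Compound 4 `O=C(NCCCCc1ccccc1)n1c(=O)oc2cc(F)ccc21` is not yet measured; it differs from compound 1 by fluoro in place of hydrogen on an aromatic carbon. Going by the values given here, two measured steps bear on this. Fluoro placed on the shared core gave a 5.3-fold lower number from compound 1 to compound 2 (0.73 log units; beyond the scatter), whereas fluoro placed on the chain gave a 1.2-fold higher number from compound 1 to compound 3 (0.07 log units; within the scatter). Compound 4 carries its fluoro on the shared core, as compound 2 does, but at a different place, so the step is expected to be a lowering of moderate size, a 2.1-fold lower number from compound 1 to compound 4 (0.33 log units; beyond the scatter). Compound 4 is estimated at 30 nM, within a range from 12 nM to 80 nM.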

Compound 4, half-maximal inhibitory concentration: 31 nM
For compound 4 the middle estimate is 1.0-fold (0.01 log units) below the measured one, within the range that was stated.
By their numbers in this assay, from the lowest: compound 2; then compound 4; then compounds 1 and 3 (each within the scatter of the next).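

In this assay, fluoro in place of hydrogen at this second aromatic carbon of the shared core also lowers the number (a 2.1-fold lower number from compound 1 to compound 4 (0.31 log units; beyond the scatter)), so a lowering beyond the scatter is not confined to the place held in compound 2. The printed values still put compound 4 (31 nM) above compound 2 (12 nM). Nothing available accounts for this difference between the two places.

From the compounds shown here alone, whether chloro, a methoxy group or an amine at this place would lower the number as fluoro does remains open. So does the outcome of fluoro at the other aromatic carbons of the core.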